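Notes on an E to Z double-bond swap

This account rests on a few compounds, and the source may have more. Where it says the series, first, only, none or still open, it means among the compounds named here.

Of the compounds shown here, two have been read so far in a functional assay on WHCO1 cells (Homo sapiens) for antiproliferative activity, read by MTT assay, with a stated time of 48 h; on this read-out higher numbers stand for weaker inhibition and lower numbers for stronger inhibition. Compound 1 (`C=CCSS/C=C/C[S+]([O-])CCC`) gives 37000 nM. Compound 2 (`C=CCSS/C=C/C[S+]([O-])CCCN1C(=O)c2ccccc2C1=O`) gives 68000 nM, which stands level with compound 1 within the scatter, so neither sets itself apart. Compound 3 (`C=CCSS/C=C\C[S+]([O-])CCCN1C(=O)c2ccccc2C1=O`) remains unmeasured. Going by the values given here, its only change from compound 2 is one of geometry: the two compounds have the same atoms and bonds; at least one stereo element is drawn with a configuration in one of them and without one in the other: 1 of 2 stereo elements differ; a double bond is drawn E in compound 2 and Z in compound 3, a double bond is drawn E in compound 2 and Z in compound 3. Among the compounds with values here, no measured pair isolates this change, so the expectation is loose. In this assay no step beyond the scatter is expected, and no clear direction. The expected size is a 1.1-fold lower number from compound 2 to compound 3 (0.05 log units; within the scatter), an estimate within the scatter. That expectation rests on compound 2 at 68000 nM alone. For compound 3 the estimated value is 60000 nM, with an expected range of 30000 nM to 120000 nM.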

Compound 3, half-maximal inhibitory concentration: 33000 nM
Estimate against measurement, compound 3: 1.8-fold (0.26 log units) above; measured number inside the range.
By their numbers in this assay, from the lowest: compounds 3, 1 and 2 (each within the scatter of the next, the first and the last beyond it).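

In this assay, geometry alone, with no atom or group entering or leaving, gives a 2.1-fold lower number from compound 2 to compound 3 (0.31 log units; beyond the scatter), so this double bond is a place where the read-out responds, and the Z form lies on the side of stronger inhibition. The step is modest and rests on a single pair, whereas compound 1 and compound 2 had shown nothing beyond the scatter. How far it can be credited to the geometry is limited by one feature of the drawings: the fact that one of compounds 2 and 3 is drawn with a defined configuration and the other without, at the place where they differ

On these data alone, whether the swap carries over when an amine or a carboxylic acid replaces the terminal group of compound 2 and compound 3 remains open. Also open, as far as these compounds go, is how a saturated chain in place of this double bond would read against either geometry.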